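Adding a Third Methyl to the Aryl Urea of Compound 1

This account rests on a few compounds, and the source may have more. Where it says the series, first, only, none or still open, it means among the compounds named here.

Compound 1 `CCCCCCCC/C=C\CCCCCCCCNC(=O)Nc1c(C)cccc1C` gives 160 nM in an assay on microsomes from intestinal mucosa for inhibition of acyl-CoA:cholesterol acyltransferase (Oryctolagus cuniculus) (on this read-out higher numbers stand for weaker inhibition and lower numbers for stronger inhibition), the lower of the two single numbers recorded there. Compound 2 `CCCCCCCC/C=C\CCCCCCCC/N=C(\S)Nc1c(C)cccc1C` is far weaker at 5400 nM, a gap well beyond the scatter, while compound 3 `CCCCCCCCCCCCCCCCCCNC(=O)Nc1c(C)cccc1C` gives 610 nM; 610 nM (2 entries) across two entries. Compound 4 `CCCCCCCC/C=C\CCCCCCCCNC(=O)Nc1c(C)cc(C)cc1C` differs from compound 1 by one change: methyl in place of hydrogen on an aromatic carbon. For the measured compounds named here, no measured pair shows this change, so nothing settles its size. With compound 1 at 160 nM as the only anchor, the added methyl is expected to move this assay only modestly, within the scatter, in either direction. The step of a 1.3-fold higher number from compound 1 to compound 4 (0.10 log units; within the scatter) is expected to be small. Compound 4 is estimated at 200 nM, within a range from 70 nM to 600 nM.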

Compound 4, half-maximal inhibitory concentration: 2900 nM
Compound 4: the middle estimate sits 15-fold (1.16 log units) below what was measured, and the stated range ends below it.
By their numbers in this assay, from the lowest: compound 1; then compounds 4 and 2 (each within the scatter of the next).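

Going from 2,6-dimethylphenyl to 2,4,6-trimethylphenyl brings an 18-fold higher number from compound 1 to compound 4 (1.26 log units; beyond the scatter) in this assay. For the compounds shown here, a single methyl on this aromatic carbon, para to a large group, is therefore enough to weaken inhibition well beyond the scatter, which the earlier compounds, all with hydrogen here, could not show. Nothing available accounts for the size of this step. On these data alone, it remains open whether fluorine, a hydroxyl or an amine on the same carbon would weaken inhibition as much, and whether the methyl would have a similar effect on compound 3.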